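Fluoro in place of chloro: a small expected step

The compounds below may be only part of what the source reports. "The series", "measured", "known", "first", "only" and "open" are said of these compounds alone.

In a functional assay on P388 cells (Mus musculus) for antiproliferative activity, read by colorimetric assay and MTT assay (on this read-out higher numbers stand for weaker inhibition and lower numbers for stronger inhibition), compound 3 `Nc1ccc(S(=O)(=O)Nc2ccc(Cl)c3c(Cl)c[nH]c23)cc1` gives 0.49 ug/mL while compound 1 `N#Cc1ccc(S(=O)(=O)Nc2ccc(Cl)c3c(Cl)c[nH]c23)cc1` gives 0.59 ug/mL and compound 2 `Nc1ccc(S(=O)(=O)Nc2cccc3c(Cl)c[nH]c23)cc1` gives 0.81 ug/mL on the same test. Compound 3 therefore stands within the usual scatter of both, level with them. Compound 4 `Nc1ccc(S(=O)(=O)Nc2ccc(F)c3c(Cl)c[nH]c23)cc1` differs from compound 3 by fluoro in place of chloro on an aromatic carbon and nothing else. The nearest evidence is a 1.7-fold lower number from compound 2 to compound 3 (0.22 log units; within the scatter) for chloro in place of hydrogen on that same carbon. The amino for cyano swap gives a 1.2-fold lower number from compound 1 to compound 3 (0.08 log units; within the scatter) at another place. Both steps lie within the scatter, so an expected step of a 1.2-fold higher number from compound 3 to compound 4 (0.09 log units; within the scatter) stays inside it too. Compound 4 is estimated at 0.6 ug/mL with an expected range from 0.3 ug/mL to 1.2 ug/mL in this assay once measured.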

Compound 4, half-maximal inhibitory concentration: 0.51 ug/mL
Beside the measured number, compound 4's estimate is 1.2-fold (0.07 log units) above it, within the range that was stated.
By their numbers in this assay, from the lowest: compounds 3, 4, 1 and 2 (each within the scatter of the next).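

In this assay, this carbon, para to a large group, takes chloro or fluoro without the number leaving the scatter: a 1.0-fold higher number from compound 3 to compound 4 (0.02 log units; within the scatter). Fluoro in place of hydrogen on the same carbon gives a 1.6-fold lower number from compound 2 to compound 4 (0.20 log units; within the scatter), also within the scatter, so neither halogen separates clearly from the hydrogen of compound 2. Nothing measured here explains this result. From the compounds shown here alone, whether a larger group on this carbon, such as methoxy or a carboxylic acid, would move the number beyond the scatter remains open. So does whether fluoro would behave alike with the cyano group of compound 1.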